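Extending the side chain of compound 3

The source may hold more compounds than are shown below. What is called first, only, known or untested is meant among the compounds shown, and "the series" means these compounds.

- compound 1 `N=c1sc2cc(OC(F)(F)F)ccc2n1CCS(N)(=O)=O`: 6 mg/kg
- compound 2 `CNS(=O)(=O)CCn1c(=N)sc2cc(OC(F)(F)F)ccc21`: 4 mg/kg
- compound 3 `CSCCn1c(=N)sc2cc(OC(F)(F)F)ccc21`: 1 mg/kg

In a functional assay on the whole organism with Rattus norvegicus as the target (a higher number here means that more compound is needed for the effect, a lower number that less compound is needed), compound 3 has the lowest number of the three, at 1 mg/kg. The two steps leading to it are modest but lie beyond the scatter: a 6.0-fold lower number from compound 1 to compound 3 (0.78 log units; beyond the scatter) and a 4.0-fold lower number from compound 2 to compound 3 (0.60 log units; beyond the scatter). The remaining step, a 1.5-fold lower number from compound 1 to compound 2 (0.18 log units; within the scatter), lies within the scatter.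

Compound 4 `CSCCCn1c(=N)sc2cc(OC(F)(F)F)ccc21` keeps everything in compound 3 except the end of the chain: (methylsulfanyl)methyl in place of methylsulfanyl on a saturated chain carbon, two bonds along the chain from an aromatic nitrogen. Here, (methylsulfanyl)methyl stands in place of methylsulfanyl, which turns the 2-(methylsulfanyl)ethyl chain into 3-(methylsulfanyl)propyl. Among the measured compounds shown here, no measured step makes this change. For the measured compounds named here, the two steps to compound 3 show only that replacing the group at this place can shift the number modestly, and they say nothing about chain length. The methylsulfanyl group itself stays in compound 4, so a small step seems more likely than a large one. With compound 3 already lowest at 1 mg/kg, a slight rise is the more cautious guess. The expected change is a 1.8-fold higher number from compound 3 to compound 4 (0.26 log units; within the scatter), which would stay within the scatter. Compound 4 is estimated at 1.8 mg/kg, with an expected range from 0.6 mg/kg to 5 mg/kg.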

Compound 4, dose for half-maximal effect: 4.2 mg/kg
The estimate for compound 4 lay 2.3-fold (0.37 log units) below the measured number; the range from low to high includes it.
By their numbers in this assay, from the lowest: compound 3; then compounds 2, 4 and 1 (each within the scatter of the next).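

In this assay, the change from the 2-(methylsulfanyl)ethyl chain to the 3-(methylsulfanyl)propyl chain gives a 4.2-fold higher number from compound 3 to compound 4 (0.62 log units; beyond the scatter), so chain length matters at this place as well as the group at its end. The earlier steps shown here could not show this, as each of them swapped the end group and left the chain length alone. Keeping methylsulfanyl therefore does not by itself preserve the low number of compound 3: the longer chain gives up that advantage over the two compounds carrying methylsulfamoyl and sulfamoyl, with a 1.1-fold higher number from compound 2 to compound 4 (0.02 log units; within the scatter) and a 1.4-fold lower number from compound 1 to compound 4 (0.15 log units; within the scatter), both within the usual scatter.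

Going by these compounds, whether the number would keep climbing with a still longer chain such as 4-(methylsulfanyl)butyl, or whether the sulfur atom itself matters, as a 2-methoxyethyl chain would test, remains open. The results show how far the number moves with the longer chain, but nothing given here accounts for that shift.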